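A few compounds are considered here, and "the series" means these few. Any claim that something is new, unique, unknown or untested is made for them only; others in the source may bear on it.

Compound 1, `COc1ccc2c(c1)CC(N(CCCN1CCN(C)CC1)C(=O)Nc1ccc(F)c(Cl)c1)CC2`, is the starting point. For the measured compounds named here, in an assay on CHO cells for binding affinity to melanin-concentrating hormone receptor 1 (Homo sapiens) (a lower number here means a stronger inhibitor, a higher number a weaker inhibitor), compound 1 gives 92 nM, the lowest of the two numbers measured so far. Going by the values given here, the only other measured compound, compound 2, `CN1CCN(CCCN(C(=O)Nc2ccc(F)c(Cl)c2)C2CCc3ccc(N)cc3C2)CC1`, gives 260 nM in this assay; the two differ in a single place, with amino in place of methoxy on an aromatic carbon, and the change amounts to a 2.8-fold higher number from compound 1 to compound 2 (0.45 log units; beyond the scatter), a modest weakening.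

Compound 3, `CCNC(=O)Nc1ccc2c(c1)CC(N(CCCN1CCN(C)CC1)C(=O)Nc1ccc(F)c(Cl)c1)CC2`, has not yet been measured. It differs from compound 1 as follows: (ethylcarbamoyl)amino in place of methoxy on an aromatic carbon

Among the compounds with values here, the one measured step that bears on this is the exchange of the same methoxy for amino in compound 2, which cost a 2.8-fold higher number from compound 1 to compound 2 (0.45 log units; beyond the scatter). Because replacing the methoxy of compound 1 with a group carrying hydrogen-bond donors weakened binding by a 2.8-fold higher number from compound 1 to compound 2 (0.45 log units; beyond the scatter), a similar modest weakening is expected for compound 3, with a step of a 2.4-fold higher number from compound 1 to compound 3 (0.38 log units; beyond the scatter). Compound 3 is therefore estimated at 220 nM, within a range from 70 nM to 700 nM.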

Compound 3, inhibition constant: 160 nM
Compound 3: middle estimate off by 1.4-fold (0.14 log units), on the high side, and the stated range covers the measured number.
By their numbers in this assay, from the lowest: compounds 1, 3 and 2 (each within the scatter of the next, the first and the last beyond it).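

Compound 3 shows that this aromatic carbon can carry a much bigger group than methoxy with no clear loss, as the change to (ethylcarbamoyl)amino gives a 1.7-fold higher number from compound 1 to compound 3 (0.24 log units; within the scatter) and so stays close to the starting point. Adding ethylcarbamoyl to the amino nitrogen gives a 1.6-fold lower number from compound 2 to compound 3 (0.21 log units; within the scatter) and likewise cannot be told apart from the plain amino group, so compound 3 sits within the scatter of both neighbours even though those two lie beyond it from each other. Nothing measured here explains why this position accepts the added chain.

Going by these compounds, whether the same holds for other groups at this position, such as a hydroxyl, a carboxylic acid or a longer chain on the urea, remains open. So does whether any group here can give a clearly lower number than methoxy.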